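Isopropyl to Dimethylcarbamoyl on a Shared Core

The source may report more compounds than this note shows. Statements on the series, on what has been measured and on what is new or still open speak of the compounds shown alone.

Compound 1 `CCOC(=O)C(CCc1ccccc1)Nc1nc2ccccc2s1` gives 520 nM
Compound 2 `Cc1ccc2oc(NC(CC3CCCCC3)c3ccccn3)nc2c1` gives 4 nM
Compound 3 `CC(C)c1ccc2oc(NC(CC3CCCCC3)c3ccccc3)nc2c1` gives 6 nM

These values come from a functional assay for inhibition, with Homo sapiens as the target; on this read-out lower numbers stand for stronger inhibition and higher numbers for weaker inhibition. There, compound 3 at 6 nM lies within the scatter of compound 2 at 4 nM and far under compound 1 at 520 nM. Compound 4 `CN(C)C(=O)c1ccc2oc(NC(CC3CCCCC3)c3ccccc3)nc2c1`, not yet measured, carries dimethylcarbamoyl in place of isopropyl on an aromatic carbon. Within the data shown here, no measured pair tests this exchange, so the expectation is loose. A moderate move to a higher number in this assay, beyond the scatter, is expected. The expected size is a 5.0-fold higher number from compound 3 to compound 4 (0.70 log units; beyond the scatter). The estimate for compound 4 is 30 nM, within an expected range of 6 nM to 150 nM.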

Compound 4, half-maximal inhibitory concentration: 170 nM
Beside the measured number, compound 4's estimate is 5.7-fold (0.75 log units) below it; measured number outside the range, above it.
By their numbers in this assay, from the lowest: compounds 2 and 3 (each within the scatter of the next); then compound 4; then compound 1.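

In this assay the exchange of isopropyl for dimethylcarbamoyl on this aromatic carbon gives a 28-fold higher number from compound 3 to compound 4 (1.45 log units; beyond the scatter) and so shows that inhibition is sensitive to the group at this place on the shared core. Among these compounds, no earlier pair tested this position, and this step is the first reading of it. No evidence at hand bears on what lies behind the step.

The compounds shown leave open how an amine, a methoxy group or a carboxylic acid would read at this place. They also leave open whether the same exchange would give a step of like size on the core of compound 2.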